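A few compounds are considered here, and "the series" means these few. Any claim that something is new, unique, unknown or untested is made for them only; others in the source may bear on it.

Measured compounds and their values:

Compound 1, `O=C(Nc1cccc(-n2cc(-c3ccncc3)c(-c3ccc(Cl)c(O)c3)n2)c1)Nc1ccc(Cl)c(Cl)c1`, gives 1060 nM in a functional assay on MCF7 cells (Homo sapiens) for inhibition, read by sulforhodamine B assay, with a stated time of 48 h; on this read-out lower numbers stand for stronger inhibition of growth and higher numbers for weaker inhibition of growth.
Compound 2, `COc1cc(-c2nn(-c3cccc(NC(=O)c4cccc(C(F)(F)F)c4)c3)cc2-c2ccncc2)ccc1Cl`, gives 1430 nM in this assay.
Compound 3, `O=C(Nc1cccc(-n2cc(-c3ccncc3)c(-c3ccc(Cl)c(O)c3)n2)c1)Nc1cc(C(F)(F)F)cc(C(F)(F)F)c1`, gives 540 nM in this assay.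

Among the three measured compounds, compound 2 has the highest number in this assay. Compound 1 stands nearest to it, within the usual scatter, so nothing can be said about an order between compound 2 and compound 1. Compound 3 stands furthest from compound 2, with a lower number that lies beyond the scatter; compound 3 carries a urea and a different set of substituents, so this gap does not speak to any single change.

Compound 4, `COc1cc(-c2nn(-c3cccc(NC(=O)c4ccccc4)c3)cc2-c2ccncc2)ccc1Cl`, is the compound yet to be measured. It differs from compound 2 in one place: hydrogen in place of trifluoromethyl on an aromatic carbon.

Within the data shown here, no pair of measured compounds differs by this change alone, so there is no measured step to lean on. The account rests on compound 2 alone, with its value of 1430 nM. The expectation is a modest step toward a higher number in this assay, of a size that may or may not clear the scatter. For compound 4 the estimated value is 2500 nM, with a range from 900 nM to 7000 nM, and the step this estimate means is a 1.7-fold higher number from compound 2 to compound 4 (0.24 log units; within the scatter).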

Compound 4, concentration for 50% growth inhibition: 335 nM
Estimate against measurement, compound 4: 7.5-fold (0.87 log units) above, outside the stated range (below it).
By their numbers in this assay, from the lowest: compounds 4, 3, 1 and 2 (each within the scatter of the next, the first and the last beyond it).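

In this assay, replacing trifluoromethyl with hydrogen on the aromatic carbon of the benzoyl part gives a 4.3-fold lower number from compound 2 to compound 4 (0.63 log units; beyond the scatter), and this step lies beyond the scatter. Among these compounds, this is the first reading of a single change in this set: within this pair, the 3-(trifluoromethyl)phenyl group is not required for growth inhibition at this place, and the plain phenyl goes with the stronger inhibition. The result holds for this one pair only and cannot be carried over to compound 1 or compound 3, each of which differs from compound 4 in more than one place, and nothing given here accounts for the direction or size of the step.

The compounds shown leave open how a methyl, a methoxy or an amine at this same place would stand against hydrogen and trifluoromethyl in this assay. They also leave open whether the same change would run the same way in a compound carrying a urea and a hydroxyl group, as compound 1 and compound 3 do, in place of the amide and methoxy of compound 4.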